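The source may report more compounds than this note shows. Statements on the series, on what has been measured and on what is new or still open speak of the compounds shown alone.

Working notes on the nitrothiazole amide series, cytotoxicity only.

The read-out throughout is an ADME assay on Vero cells (Chlorocebus sabaeus) for cytotoxicity, read by MTT assay, with a stated time of 48 h; a lower number here means that less compound is tolerated, a higher number that more compound is tolerated. Compound 1 `O=C(CN1CCCCC1)Nc1nc2ccc([N+](=O)[O-])cc2s1` carries a piperidin-1-yl on the amide chain. In this assay compound 1 gives > 1000000 nM, which is a limit of the assay and not a number. Compound 2 `O=C(CN1CCCCC1)Nc1ncc([N+](=O)[O-])s1` has the same amide chain on a different core; the difference between the two cores is not broken down here. In this assay compound 2 gives > 1000000 nM, again a limit. Compound 3 `CCN(CC)CC(=O)Nc1ncc([N+](=O)[O-])s1` is the open-chain counterpart of compound 2, the change being (diethylamino in place of piperidin-1-yl on a saturated chain carbon bound to a carbonyl carbon). In this assay compound 3 gives > 1000000 nM, also a limit. The step that the two limits leave unreadable from compound 2 to compound 3 therefore cannot be sized from the two limits.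

Compound 4 `CCN(CC)CC(=O)Nc1nc2ccc([N+](=O)[O-])cc2s1` has not been measured. It stands to compound 1 as compound 3 stands to compound 2, differing by diethylamino in place of piperidin-1-yl on a saturated chain carbon bound to a carbonyl carbon. The two place descriptions agree word for word, so the same change occurs twice among the four compounds. Every value shown sits at the limit of > 1000000 nM in this assay, at which 3 of the 3 values shown sit, so nothing seen so far separates the two amines or the two cores in this read-out.

The expected step is a step that the limit leaves unreadable from compound 1 to compound 4, standing beside a step that the two limits leave unreadable from compound 2 to compound 3, and it rests on the limit of > 1000000 nM in this assay, at which 3 of the 3 values shown sit, only. Compound 4 is estimated to give 1500000 nM in this assay, with an expected range from 500000 nM to 5000000 nM, and is most likely to be reported as a limit.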

Compound 4, half-maximal cytotoxic concentration: > 1000000 nM
Compound 4: only a limit was reported; the forecaster's own chance of this, stated with the estimate: 85%; the middle value does not contradict the limit.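

In this assay compound 4 gives > 1000000 nM, which is a limit of the assay and not a number. No step can be read from compound 1 to compound 4, so the result adds no size to the change of amine, the reason being: the limit of > 1000000 nM in this assay, at which 4 of the 4 values shown sit.

On these data alone, whether diethylamino and piperidin-1-yl, or the two cores, differ at all in this assay stays open.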